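This account rests on a few compounds, and the source may have more. Where it says the series, first, only, none or still open, it means among the compounds named here.

Measured in a functional assay for activation of Alpha-1A adrenergic receptor (Homo sapiens), read by calcium flux; on this read-out higher numbers stand for an effect only at larger amounts of compound and lower numbers for an effect already at smaller amounts:
compound 1 `Cc1nc(-c2ccccc2NCC2=NCCN2)co1` gives 324 nM
compound 2 `Cc1noc(-c2ccccc2NCC2=NCCN2)n1` gives 661 nM
compound 3 `Nc1nccc(-c2ccccc2NCC2=NCCN2)n1` gives 42.7 nM

Among the measured compounds shown here, compound 2 gives the highest of the three numbers; compound 1 stands nearest, compound 3 furthest, and the only single-point step among them is a 2.0-fold higher number from compound 1 to compound 2 (0.31 log units; beyond the scatter). Compound 4 `CC/C(=N/OC)c1ccccc1NCC1=NCCN1` is not yet measured. It differs from compound 2 in one place: a group of 6 heavy atoms (4 carbon, 1 nitrogen, 1 oxygen; no ring) in place of a group of 6 heavy atoms (3 carbon, 2 nitrogen, 1 oxygen; one five-membered aromatic ring with 3 hetero atoms), on an aromatic carbon. For the measured compounds named here, no measured step exchanges a ring for an open chain. Going by the values given here, the one comparable step, a 2.0-fold higher number from compound 1 to compound 2 (0.31 log units; beyond the scatter), swapped two five-membered aromatic rings and moved the number modestly, while the numbers of compound 2 and compound 3 show that this group alone covers a wider range. The direction for compound 4 is therefore open. For compound 4 an expected step of a 1.3-fold lower number from compound 2 to compound 4 (0.12 log units; within the scatter) is taken, small against that uncertainty. The estimate for compound 4 in this assay is 500 nM, with a range of 120 nM to 2000 nM.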

Compound 4, half-maximal effective concentration: 87.1 nM
Beside the measured number, compound 4's estimate is 5.7-fold (0.76 log units) above it; measured number below the stated range.
By their numbers in this assay, from the lowest: compound 3; then compound 4; then compound 1; then compound 2.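

In this assay, a ring is not required on this aromatic carbon: the open chain gives a lower number than either five-membered aromatic ring (a 7.6-fold lower number from compound 2 to compound 4 (0.88 log units; beyond the scatter)) and (a 3.7-fold lower number from compound 1 to compound 4 (0.57 log units; beyond the scatter)). Both steps run the same way and lie beyond the scatter, so the change from ring to open chain is not neutral here. No measurement at hand accounts for this.

The compounds shown leave open which part of the chain matters. Going by these compounds, how a longer chain, an amine or a carboxylic acid on this aromatic carbon would read also remains unknown.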